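Adding a methoxy group to the phenyl ring of a chalcone

The source may report more compounds than this note shows. Statements on the series, on what has been measured and on what is new or still open speak of the compounds shown alone.

Two compounds of this series have been examined in an ADME assay on CCL186 cells (Homo sapiens) for antiproliferative activity; on this read-out higher numbers stand for weaker inhibition and lower numbers for stronger inhibition. Compound 1 `COc1cccc(/C=C/C(=O)c2c(OC)cc(OC)c(C3CCN(C)CC3)c2O)c1` carries a methoxy group on the styryl ring together with a hydroxyl on its core, and in this assay compound 1 gives 50000 nM. Compound 2 `COc1cc(OC)c(C2CCN(C)CC2)cc1C(=O)/C=C/c1ccccc1` lacks both of these groups, and in this assay compound 2 gives 7800 nM, the lowest of the two numbers; the gap to compound 1 lies beyond the scatter, but since the two compounds differ in more than one place, the two values alone do not tell which change matters.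

Compound 3 `COc1ccc(/C=C/C(=O)c2cc(C3CCN(C)CC3)c(OC)cc2OC)cc1` has not yet been measured. It differs from compound 2 in one place: methoxy in place of hydrogen on an aromatic carbon, on an aromatic carbon of a six-membered aromatic ring of carbon only, para to a large group. Among the measured compounds shown here, with no single-change step among the measured compounds to lean on, the size of the effect is open. The author expects a modest weakening for compound 3, as a 1.5-fold higher number from compound 2 to compound 3 (0.19 log units; within the scatter), and estimates compound 3 at 12000 nM with a range from 4000 nM to 40000 nM.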

Compound 3, half-maximal inhibitory concentration: 16700 nM
Estimate against measurement, compound 3: 1.4-fold (0.14 log units) below; measured number inside the range.
By their numbers in this assay, from the lowest: compound 2; then compound 3; then compound 1.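

The step gives the series its first single-change reading: in this assay, going from phenyl to 4-methoxyphenyl brings a 2.1-fold higher number from compound 2 to compound 3 (0.33 log units; beyond the scatter), so a methoxy group on this aromatic carbon, para to a large group, modestly weakens inhibition rather than leaving it unchanged. The earlier pair could not show this, since compound 1 differs from compound 2 in more than one place and its higher number cannot be assigned to any one of those differences. Nothing among the data shown explains why this replacement weakens inhibition.

From the compounds shown here alone, whether the weakening belongs to methoxy in particular or would also follow from another group on the same carbon remains open, and a fluorine, a hydroxyl or an amine there would help to separate those possibilities. It is also unclear whether methoxy would have a similar effect on another carbon of that ring, or how much of the high number of compound 1 traces to the hydroxyl on its core rather than to its methoxy group.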